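Swapping a methoxyphenoxy for a tert-butylphenoxy on a coumarin amide

The compounds below may be only part of what the source reports. "The series", "measured", "known", "first", "only" and "open" are said of these compounds alone.

Measured compounds:
Compound 1, `COc1cccc(Oc2ccc3cc(NC(=O)c4ccc(OC(C)=O)c(CC=C(C)C)c4)c(=O)oc3c2C)c1`: 13700 nM
Compound 2, `CC(=O)Oc1ccc(C(=O)Nc2cc3ccc(Oc4ccc(C(C)(C)C)cc4)c(C)c3oc2=O)cc1CC=C(C)C`: 72400 nM
Compound 3, `COc1cccc(Oc2ccc3cc(NC(=O)c4ccc(OC)c(-c5cccc(OC)c5)c4)c(=O)oc3c2C)c1`: only a limit

In a functional assay on SK-BR-3 cells (Homo sapiens) for antiproliferative activity (a lower number here means a stronger inhibitor, a higher number a weaker inhibitor), compound 1 gives 13700 nM, and compound 2 gives 72400 nM. The change between them is 4-(tert-butyl)phenyl in place of 3-methoxyphenyl on an oxygen on an aromatic ring, and it made a step of a 5.3-fold higher number from compound 1 to compound 2 (0.72 log units; beyond the scatter). For compound 3 this assay reports only a limit, > 100000 nM, not a number. How the core of compound 3 differs from that of compound 1 is not broken down here. Compound 4, `COc1cccc(-c2cc(C(=O)Nc3cc4ccc(Oc5ccc(C(C)(C)C)cc5)c(C)c4oc3=O)ccc2OC)c1`, is not yet measured; it differs from compound 3 by 4-(tert-butyl)phenyl in place of 3-methoxyphenyl on an oxygen on an aromatic ring, at a place described in the same words as before, so this is the same change. Because the earlier step was a 5.3-fold higher number from compound 1 to compound 2 (0.72 log units; beyond the scatter), compound 4 is expected to be weaker again, by an estimated step that the limit leaves unreadable from compound 3 to compound 4. For compound 4 the expected value is 300000 nM, most likely again only a limit.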

Compound 4, half-maximal inhibitory concentration: > 100000 nM
Compound 4 ended at the assay's limit; the forecaster's own chance of this, stated with the estimate: 85%; the middle value lies beyond the limit too.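

For the compounds shown here, compound 3 and compound 4 both end at a limit rather than a number, so no step between them can be read: the limit of > 100000 nM in this assay, at which 2 of the 4 values shown sit.

Still open, on these data alone, is whether the change from 3-methoxyphenoxy to 4-(tert-butyl)phenoxy weakens compounds with the core of compound 3, as it did with the core of compound 1.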